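Swapping pyrrolidin-2-yl for 4-hydroxyphenyl on the core

The compounds below may be only part of what the source reports. "The series", "measured", "known", "first", "only" and "open" are said of these compounds alone.

- compound 1 `COc1ccc(-c2noc(C3CCCN3)n2)cc1OC1CCCC1`: > 1000000 nM
- compound 2 `COc1cc(-c2noc(-c3ccncc3)n2)ccc1OCc1ccccc1`: > 1000000 nM

In a functional assay on PC-3 cells (Homo sapiens) for antiproliferative activity, read by MTT assay, with a stated time of 24 h (on this read-out higher numbers stand for weaker inhibition and lower numbers for stronger inhibition), compound 1 gives > 1000000 nM. That value is a limit and not a number. Compound 2 stands at the same limit, so the record so far reads (the limit of > 1000000 nM in this assay, at which 2 of the 2 values shown sit).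

Compound 3 `COc1ccc(-c2noc(-c3ccc(O)cc3)n2)cc1OC1CCCC1` alters compound 1 in one place: 4-hydroxyphenyl in place of pyrrolidin-2-yl on an aromatic carbon, with 4-hydroxyphenyl in place of pyrrolidin-2-yl on an aromatic carbon. Among the compounds with values here, no measured step yet shows what such a swap does. A modest move toward stronger inhibition is expected, an at least 5.0-fold lower number from compound 1 to compound 3 (0.69 log units; beyond the scatter), although another limit remains quite possible. The estimate for compound 3 is 200000 nM, with an expected range from 15000 nM to 1000000 nM.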

Compound 3, half-maximal inhibitory concentration: 162000 nM
The estimate for compound 3 lay 1.2-fold (0.09 log units) above the measured number; low and high end bracket the measured number.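

In this assay, placing 4-hydroxyphenyl in place of pyrrolidin-2-yl on an aromatic carbon gives an at least 6.1-fold lower number from compound 1 to compound 3 (0.79 log units; beyond the scatter). This step is only a minimum, as the value of compound 1 is a limit. Compound 3 is the only compound shown that has left that limit, so this position can respond to a change of group: the limit of > 1000000 nM in this assay, at which 2 of the 3 values shown sit.

From the compounds shown here alone, whether the step comes from the hydroxy group or from the aromatic ring itself stays open, and a plain phenyl here would separate the two. Going by these compounds, how an amine or a carboxylic acid on that ring would read also remains open.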